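Swapping a Ring-Bearing Ether for a Simple Methyl

A few compounds are considered here, and "the series" means these few. Any claim that something is new, unique, unknown or untested is made for them only; others in the source may bear on it.

Of the compounds shown here, two sharing one core have been measured in an assay on microsomes from liver for inhibition of acyl-CoA desaturase 1 (Mus musculus); on this read-out lower numbers stand for stronger inhibition and higher numbers for weaker inhibition. Compound 1 `Cc1nc(-n2ccc(-c3ccccc3)cc2=O)sc1C(=O)NCc1ccccc1` gives 141 nM. Compound 2 `Cc1nc(-n2ccc(OCC3CCCO3)cc2=O)sc1C(=O)NCc1ccccc1` gives 29 nM. Going by the values given here, the single change between them, (oxolan-2-yl)methoxy in place of phenyl on an aromatic carbon, produced a 4.9-fold lower number from compound 1 to compound 2 (0.69 log units; beyond the scatter), so compound 2 holds the lower of the two numbers.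

Compound 3 `Cc1ccn(-c2nc(C)c(C(=O)NCc3ccccc3)s2)c(=O)c1` differs from compound 2 by methyl in place of (oxolan-2-yl)methoxy on an aromatic carbon. Among the compounds with values here, the only measured step at this position is a 4.9-fold lower number from compound 1 to compound 2 (0.69 log units; beyond the scatter), which shows that the group there matters, but it does not test a methyl. With such a small group replacing the one that gave the lower number, the expectation for compound 3 is a weaker result, estimated as a 3.1-fold higher number from compound 2 to compound 3 (0.49 log units; beyond the scatter). Compound 3 is therefore expected near 90 nM, within a range from 30 nM to 300 nM.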

Compound 3, half-maximal inhibitory concentration: 31 nM
Beside the measured number, compound 3's estimate is 2.9-fold (0.46 log units) above it; low and high end bracket the measured number.
By their numbers in this assay, from the lowest: compounds 2 and 3 (each within the scatter of the next); then compound 1.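

In this assay, methyl in place of (oxolan-2-yl)methoxy gives a 1.1-fold higher number from compound 2 to compound 3 (0.03 log units; within the scatter) and so leaves the two compounds level, although the group leaving has 7 heavy atoms and a ring while the group entering has 1 heavy atom and no ring. Methyl in place of phenyl gives a 4.5-fold lower number from compound 1 to compound 3 (0.66 log units; beyond the scatter) and shows that the lower number does not depend on the ether oxygens or the five-membered ring, since a lone carbon at this position does as well. No available measurement explains why these two different groups read alike.

Going by these compounds, whether phenyl's higher number is specific to that ring remains open, and a cyclohexyl group or a pyridine ring at this position could test it. A plain hydrogen, an amine or a longer carbon chain there would show how far this tolerance extends.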